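The source may hold more compounds than are shown below. What is called first, only, known or untested is meant among the compounds shown, and "the series" means these compounds.

Of the compounds shown here, two of a shared core have been measured in an assay on cells for inhibition of histone deacetylase 4 (Homo sapiens), read by fluorescence, with a stated time of 30 min; a lower number here means a stronger inhibitor, a higher number a weaker inhibitor. Compound 1 `Cc1ccc(C2CC(c3ccc(F)cc3)=NN2C(=O)COc2ccc(/C=C3/SC(=O)NC3=O)cc2)cc1` gives 1800 nM, and compound 2 `O=C1NC(=O)/C(=C\c2ccc(OCC(=O)N3N=C(c4ccc(F)cc4F)CC3c3ccc(F)cc3)cc2)S1` gives 1500 nM. Compound 2 holds the lower of the two numbers, but the gap to compound 1 is within the scatter of repeated measurements, so the two readings cannot be told apart with confidence. Among the measured compounds shown here, the two structures differ in more than one place, so no single step between measured compounds is available to guide the next comparison.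

Compound 3 `Cc1ccc(C2CC(c3ccc(F)cc3F)=NN2C(=O)COc2ccc(/C=C3/SC(=O)NC3=O)cc2)cc1` is derived from compound 2 by a single change: methyl in place of fluoro on an aromatic carbon. The swap removes one fluorine and brings in one carbon, with no change in donors, acceptors, ring count or charge. Nothing in the measured pair isolates this swap, and the two numbers in hand sit close together, so for this assay the step is expected to be small, in no firm direction, and not beyond the scatter: the expected step of a 1.1-fold higher number from compound 2 to compound 3 (0.05 log units; within the scatter). Compound 3 is therefore estimated at 1700 nM, with a range from 800 nM to 3600 nM.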

Compound 3, half-maximal inhibitory concentration: 1500 nM
Beside the measured number, compound 3's estimate is 1.1-fold (0.05 log units) above it; the range from low to high includes it.
By their numbers in this assay, from the lowest: compounds 2, 3 and 1 (each within the scatter of the next).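

In this assay, putting methyl in place of fluoro on an aromatic carbon para to a large group, the change from 4-fluorophenyl to 4-methylphenyl, gives no change at the digits printed from compound 2 to compound 3 (within the scatter). This shows that, in this setting, the position holds either group with no difference that can be read. The new compound also supplies a second single-place comparison, which the earlier pair could not offer: fluoro in place of hydrogen on an aromatic carbon gives a 1.2-fold lower number from compound 1 to compound 3 (0.08 log units; within the scatter), so neither single change separates the compounds, and the three readings cannot be put in any firm order. No evidence is given that bears on these results.

Only fluoro and methyl are shown at the para position, so it stays open whether an amine, a methoxy group or a carboxylic acid there would move the number beyond the scatter. On these data alone, it also stays open whether fluoro in place of hydrogen would read the same with 4-fluorophenyl rather than 4-methylphenyl on the shared core.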